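Methyl to trifluoromethyl on the benzyl ring: a bromoacrylamide

The compounds below may be only part of what the source reports. "The series", "measured", "known", "first", "only" and "open" are said of these compounds alone.

Measured compounds in a functional assay on HeLa cells (Homo sapiens) for cytotoxicity, read by cell counting, with a stated time of 4 days; on this read-out higher numbers stand for weaker inhibition and lower numbers for stronger inhibition:
- compound 1 `C=C(Br)C(=O)Nc1ccc(/C=C2\SC(=O)N(Cc3ccc(C)cc3)C2=O)cc1` gives 8900 nM
- compound 2 `Nc1ccc(/C=C2\SC(=O)N(Cc3cccc(F)c3)C2=O)cc1` gives 250000 nM
- compound 3 `Nc1ccc(/C=C2\SC(=O)N(Cc3cccc(Cl)c3)C2=O)cc1` gives 24000 nM

Compound 1 has the lowest number of the three, so it is the strongest inhibitor in this assay; compound 3 stands nearest to it and compound 2 furthest, both gaps beyond the scatter. The new compound, compound 4 `C=C(Br)C(=O)Nc1ccc(/C=C2\SC(=O)N(Cc3ccc(C(F)(F)F)cc3)C2=O)cc1`, differs from compound 1 in one place: trifluoromethyl in place of methyl on an aromatic carbon.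

For the measured compounds named here, no measured step matches this change. Going by the values given here, the only step recorded, a 10-fold lower number from compound 2 to compound 3 (1.02 log units; beyond the scatter), swaps one halogen for another on the same benzyl ring in compounds that lack the bromoacrylamide, so it speaks to a different exchange and a different pair of compounds. It shows that the group on that ring can move the number a great deal, but gives no direction for trifluoromethyl in place of methyl. Among the compounds with values here, with no step that bears directly, the expectation for compound 4 is a number near that of compound 1, with a change that may stay within the scatter and a wide range either way. Compound 4 is therefore estimated at 7000 nM, spanning 2000 nM to 25000 nM, which means an expected step of a 1.3-fold lower number from compound 1 to compound 4 (0.10 log units; within the scatter).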

Compound 4, half-maximal inhibitory concentration: 13000 nM
The estimate for compound 4 lay 1.9-fold (0.27 log units) below the measured number, within the range that was stated.
By their numbers in this assay, from the lowest: compounds 1, 4 and 3 (each within the scatter of the next, the first and the last beyond it); then compound 2.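

In this assay, placing trifluoromethyl instead of methyl on this carbon of the benzyl ring in a bromoacrylamide gives a 1.5-fold higher number from compound 1 to compound 4 (0.16 log units; within the scatter), so a group of four heavy atoms takes the place of a single carbon without a change that can be told from the usual scatter. For the compounds shown here, the earlier compounds showed only that a halogen exchange on the benzyl ring of compounds lacking the bromoacrylamide can matter a great deal, with a 10-fold lower number from compound 2 to compound 3 (1.02 log units; beyond the scatter), whereas this pair shows an exchange on that ring that leaves the number in place. Nothing measured here explains this result.

As far as these compounds go, whether the same holds for other groups at this carbon, such as an amine, a carboxylic acid or a longer alkyl chain, remains open. From the compounds shown here alone, the contribution of the bromoacrylamide is also open: compound 1 and compound 3 differ in more than one place, so their numbers cannot isolate its effect.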